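A few compounds are considered here, and "the series" means these few. Any claim that something is new, unique, unknown or untested is made for them only; others in the source may bear on it.

Of the compounds shown here, three built on one shared core have been measured in an assay on CHO-K1 cells for displacement of a labelled ligand from adenosine receptor A1 (Homo sapiens), read by scintillation counting, with a stated time of 60 min; on this read-out lower numbers stand for stronger inhibition and higher numbers for weaker inhibition. Compound 1 `CCCCC/C=C/C=C/C=N/Nc1nc(N)c2ncn([C@@H]3O[C@H](CO)[C@@H](O)[C@H]3O)c2n1` gives 2 nM in this assay, the lowest of the three numbers; both gaps to the other two lie beyond the usual scatter, so compound 1 is the strongest binder seen so far. Compound 3 `Nc1nc(N/N=C/c2cccc(OCc3ccccc3)c2)nc2c1ncn2[C@@H]1O[C@H](CO)[C@@H](O)[C@H]1O` gives 13 nM, the nearest to compound 1. Compound 2 `CC(/C=N/Nc1nc(N)c2ncn([C@@H]3O[C@H](CO)[C@@H](O)[C@H]3O)c2n1)Cc1ccc(C(C)C)cc1` gives 9500 nM, the furthest away. Compound 4 `Nc1nc(N/N=C/c2ccc3ncccc3c2)nc2c1ncn2[C@@H]1O[C@H](CO)[C@@H](O)[C@H]1O` has not yet been measured. It differs from compound 1 in one place: a group of 10 heavy atoms (9 carbon, 1 nitrogen; one six-membered aromatic ring of carbon only, one six-membered aromatic ring with 1 hetero atom) in place of a group of 9 heavy atoms (9 carbon; no ring), on a carbon with a double bond to nitrogen. Going by the values given here, no measured pair shows exactly this change, so the size of the step cannot be read off another pair. At that same carbon, compared with compound 1, compound 3 also differs and still gives 13 nM, a moderate loss rather than a collapse. The step from compound 1 to compound 4 is expected to be a 10-fold higher number from compound 1 to compound 4 (1.00 log units; beyond the scatter), a weakening beyond the scatter. Compound 4 is therefore estimated at 20 nM, within a range from 4 nM to 100 nM.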

Compound 4, inhibition constant: 9.8 nM
Compound 4: middle estimate off by 2.0-fold (0.31 log units), on the high side; the range from low to high includes it.
By their numbers in this assay, from the lowest: compound 1; then compounds 4 and 3 (each within the scatter of the next); then compound 2.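

Replacing the ring-free chain with quinolin-6-yl gives a 4.9-fold higher number from compound 1 to compound 4 (0.69 log units; beyond the scatter), a modest loss, so binding in this assay stays strong when two aromatic rings, one holding a nitrogen, stand on this carbon with a double bond to nitrogen. Compound 3 gives 13 nM and compound 4 gives 9.8 nM, within the scatter of each other, so two different ring-bearing groups here give matching results, although compound 2, which also carries a ring, goes against any simple rule with 9500 nM. No measurement here explains these differences.

Going by these compounds, whether the ring nitrogen of quinolin-6-yl matters stays open, and a naphthyl group, with carbon only in both rings, would test this directly. On these data alone, how a saturated chain such as octyl would compare with the chain of compound 1 also remains open.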